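The source may hold more compounds than are shown below. What is called first, only, known or untested is meant among the compounds shown, and "the series" means these compounds.

Measured in a physicochemical assay for permeability, using PAMPA; on this read-out lower numbers stand for lower permeability and higher numbers for higher permeability:
- Compound 1 `Cc1ccccc1-c1nc(CN2CCC(C(=O)NCCCN3CCC(C)CC3)CC2)c(C)o1`: 425 10^-6 cm/s
- Compound 2 `Cc1ccccc1-c1nc(CN2CCC(C(=O)N3CCN(C4CCN(C)CC4)CC3)CC2)c(C)o1`: < 3.2 10^-6 cm/s

Compound 2 gives < 3.2 10^-6 cm/s in this assay, and this is a limit of the assay, not a number. Among the compounds with values here, compound 1 gives 425 10^-6 cm/s, the only true number so far. Within the data shown here, the two measured compounds do not form a pair that differs in one place, so no measured step sets a size for what follows.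

Compound 3 `Cc1ccccc1-c1nc(CN2CCC(C(=O)N3CCN(CCN(C)C)CC3)CC2)c(C)o1` differs from compound 2 in one place: 2-(dimethylamino)ethyl in place of 1-methylpiperidin-4-yl on an amine nitrogen in a ring. In words, 2-(dimethylamino)ethyl stands in place of 1-methylpiperidin-4-yl on an amine nitrogen in a ring, and the rest of the structure is unchanged.

With so much of compound 2 kept, compound 3 is expected to stay close to it in this assay, with no move beyond the scatter, and it may again return only a limit. The estimated change is an at least 1.5-fold higher number from compound 2 to compound 3 (0.19 log units; that floor lies within the scatter). For compound 3 the expected value is 5 10^-6 cm/s, with an estimated range of 1.5 10^-6 cm/s to 40 10^-6 cm/s.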

Compound 3, apparent permeability: 14 10^-6 cm/s
Beside the measured number, compound 3's estimate is 2.8-fold (0.45 log units) below it; measured number inside the range.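

In this assay, 2-(dimethylamino)ethyl in place of 1-methylpiperidin-4-yl on an amine nitrogen in a ring gives an at least 4.3-fold higher number from compound 2 to compound 3 (0.64 log units; beyond the scatter), which shows that the read-out can move at this position and gives the position its first true number. That step starts from a limit of the assay and not a number, so it sets only a floor for the size of the change: the limit of < 3.2 10^-6 cm/s in this assay, at which 1 of the 3 values shown sits. Within the data shown here, compound 3 also gives the first step to compound 1, a 30-fold lower number from compound 1 to compound 3 (1.48 log units; beyond the scatter), where the group on the carbonyl carbon changes from one with one six-membered non-aromatic ring with 1 hetero atom to one with one six-membered non-aromatic ring with 2 hetero atoms, while its heavy-atom count stays the same.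

The compounds shown leave open whether a longer chain ending in the same dimethylamino group, or a plain methyl on that ring nitrogen, would take the read-out further in this assay. They also leave open which part of the exchanged group on the carbonyl carbon, the amide hydrogen or the extra ring nitrogen, accounts for the large step from the core of compound 1.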